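This account rests on a few compounds, and the source may have more. Where it says the series, first, only, none or still open, it means among the compounds named here.

Three compounds have been measured in a functional assay on HepG2 cells (Homo sapiens) for cytotoxicity, read by MTT assay, with a stated time of 48 h; on this read-out lower numbers stand for stronger inhibition and higher numbers for weaker inhibition:

compound 1, `COc1cc(-c2nnc3n2NC(c2cccs2)C(C(=O)c2ccccc2)S3)cc(OC)c1OC`, gives > 100000 nM, which is a limit of the assay.
compound 2, `COc1cc(-c2nnc3n2NC(c2cccs2)C(C(=O)c2ccc(F)cc2)S3)cc(OC)c1OC`, gives 54200 nM.
compound 3, `COc1cc(-c2nnc3n2NC(c2ccco2)C(C(=O)c2ccco2)S3)cc(OC)c1OC`, gives > 100000 nM, which is a limit of the assay.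

Compound 3 therefore stands at the limit of > 100000 nM in this assay, at which 2 of the 3 values shown sit, so its number is a limit and not a measured value. Compound 4, `COc1cc(-c2nnc3n2NC(c2ccco2)C(C(=O)c2cccc(Br)c2)S3)cc(OC)c1OC`, differs from compound 3 by 3-bromophenyl in place of furan-2-yl on a carbonyl carbon. Among the compounds with values here, the one step measured between compounds that differ in a single place is an at least 1.8-fold lower number from compound 1 to compound 2 (0.26 log units; that floor lies within the scatter), a fluoro in place of hydrogen on an aromatic carbon, whose size sits within the scatter. Within the data shown here, that step does not bear directly on an exchange of furan-2-yl for 3-bromophenyl, and no measured pair covers it. What the values show is that compound 1 sits at the limit. Compound 2, which carries a halogen on its aromatic ring, gives a measured number. Compound 4 also carries a halogen on an aromatic ring at the carbonyl, so a number near the limit is expected for it. Compound 4 is estimated at 70000 nM, with a range from 30000 nM to 150000 nM. The expected step is an at least 1.4-fold lower number from compound 3 to compound 4 (0.15 log units; that floor lies within the scatter), which is not a change beyond the scatter.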

Compound 4, half-maximal inhibitory concentration: > 100000 nM
Compound 4: a limit, no number (the forecaster's own chance of this, stated with the estimate: 45%); at least 1.4-fold (0.15 log units) between middle value and limit.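

In this assay compound 4 gives > 100000 nM, which is a limit of the assay. Compound 3 also sits at a limit, so no step can be read for 3-bromophenyl in place of furan-2-yl between compound 3 and compound 4: the limit of > 100000 nM in this assay, at which 3 of the 4 values shown sit. The compounds shown leave open whether this exchange alters the cytotoxicity of compound 3 at all.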